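Trimming the Aryl Ether Down to a Methyl Ether

The source may hold more compounds than are shown below. What is called first, only, known or untested is meant among the compounds shown, and "the series" means these compounds.

Among three related compounds, compound 2 `FC(F)(F)Oc1ccc(Oc2ccnc(N3CCC(NC(=S)Nc4cccnc4)CC3)c2)cc1` stands highest in an assay on membranes from brain for binding affinity to Lysophosphatidylserine lipase ABHD12 (Mus musculus), read by fluorescence, with a stated time of 20 min (on this read-out higher numbers stand for weaker inhibition and lower numbers for stronger inhibition), at 410 nM. Compound 1 `FC(F)(F)Oc1ccc(Oc2ccnc(N3CCC(NC(=S)Nc4cccnc4)CC3)c2Cl)cc1` gives 25 nM in this assay, and compound 3 `N#Cc1c(Oc2ccc(OC(F)(F)F)cc2)ccnc1N1CCC(NC(=S)Nc2cccnc2)CC1` gives 180 nM. All three measured steps change a single group on an aromatic carbon: a 16-fold higher number from compound 1 to compound 2 (1.21 log units; beyond the scatter), a 7.2-fold higher number from compound 1 to compound 3 (0.86 log units; beyond the scatter) and a 2.3-fold lower number from compound 2 to compound 3 (0.36 log units; beyond the scatter). Compound 4 `COc1ccnc(N2CCC(NC(=S)Nc3cccnc3)CC2)c1` differs from compound 2 in another place: methyl in place of 4-(trifluoromethoxy)phenyl on an oxygen on an aromatic ring. For the measured compounds named here, none of the measured steps touches this part of the structure, so they offer no direct guide. Removing so much of one end of the molecule seems more likely to weaken binding than to strengthen it, so in this assay compound 4 is expected to show a 12-fold higher number from compound 2 to compound 4 (1.09 log units; beyond the scatter). The estimate for compound 4 is 5000 nM, within a range from 1000 nM to 30000 nM.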

Compound 4, half-maximal inhibitory concentration: > 5000 nM
Compound 4 ended at the assay's limit (the forecaster's own chance of this, stated with the estimate: 30%); the middle value lies on the limit itself.
By their numbers in this assay, from the lowest: compound 1; then compound 3; then compound 2. At a limit, above all of these: compound 4.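

In this assay, methyl in place of 4-(trifluoromethoxy)phenyl on this oxygen gives an at least 12-fold higher number from compound 2 to compound 4 (1.08 log units; beyond the scatter). The earlier steps shown here changed only a group on an aromatic carbon, whereas this one shows that inhibition also weakens when the far end of the molecule is cut back. Compound 4 sits at a limit of the assay, so the full size of the step stays unknown: the limit of > 5000 nM in this assay, at which 1 of the 4 values shown sits.

From the compounds shown here alone, whether a plain phenyl or a benzyl on this oxygen would keep the number near that of compound 2 stays open. So does how much of the loss belongs to the ring and how much to the trifluoromethoxy group.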